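Benzyloxy for chloro on the aryl ring of compound 2

The compounds below may be only part of what the source reports. "The series", "measured", "known", "first", "only" and "open" are said of these compounds alone.

Compound 1 `COc1ccc(C2=NN(C(=O)c3cncc(Br)c3)C(c3ccc(Cl)cc3)C2)cc1` gives 1290 nM in a functional assay on WM 266-4 cells (Homo sapiens) for antiproliferative activity, read by MTT assay, with a stated time of 24 h; a lower number here means a stronger inhibitor of growth, a higher number a weaker inhibitor of growth.
Compound 2 `COc1ccc(C2=NN(C(=O)c3ccc(C)nc3Cl)C(c3ccc(Cl)cc3)C2)cc1` gives 1440 nM in this assay.
Compound 3 `COc1ccc(C2=NN(C(=O)c3cccnc3Cl)C(c3ccc(Cl)cc3)C2)cc1` gives 780 nM in this assay.

Compound 2 has the highest number of the three, yet its steps to the others are small: a 1.1-fold higher number from compound 1 to compound 2 (0.05 log units; within the scatter) and a 1.8-fold lower number from compound 2 to compound 3 (0.27 log units; within the scatter), both within the scatter, so the three cannot be ranked. Compound 4 `COc1ccc(C2=NN(C(=O)c3ccc(C)nc3Cl)C(c3ccc(OCc4ccccc4)cc3)C2)cc1` arises from compound 2 by one change, (benzyloxy in place of chloro on an aromatic carbon). For the measured compounds named here, none of the measured steps touches this ring; the steps of a 1.7-fold lower number from compound 1 to compound 3 (0.22 log units; within the scatter) and a 1.8-fold lower number from compound 2 to compound 3 (0.27 log units; within the scatter) concern only the pyridine on the carbonyl carbon, and all were within the scatter. Going by the values given here, no measured step therefore bears on this change, and the expectation rests on the flat picture seen so far. The expected step is a 1.0-fold higher number from compound 2 to compound 4 (0.02 log units; within the scatter). Compound 4 is estimated at 1500 nM, with a range from 400 nM to 6000 nM.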

Compound 4, concentration for 50% growth inhibition: 10500 nM
Compound 4: the middle estimate sits 7.0-fold (0.85 log units) below what was measured; measured number outside the range, above it.
By their numbers in this assay, from the lowest: compounds 3, 1 and 2 (each within the scatter of the next); then compound 4.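

For the compounds shown here, this is the first step that lies beyond the scatter: in this assay, there is a 7.3-fold higher number from compound 2 to compound 4 (0.86 log units; beyond the scatter). The earlier steps shown here all concerned the pyridine on the carbonyl carbon, whereas this one shows that the aromatic carbon para to a large group is sensitive to change, with benzyloxy giving weaker growth inhibition than chloro. Nothing available explains why this swap weakens growth inhibition.

Going by these compounds, it remains open whether an amine or an ethoxy group here would stay close to compound 2. Whether benzyloxy would have a similar effect with the pyridine of compound 3 is also unknown.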